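Methyl on the Indole Nitrogen: From Compound 3 to Compound 4

The compounds below may be only part of what the source reports. "The series", "measured", "known", "first", "only" and "open" are said of these compounds alone.

Measured compounds:
compound 1, `Cn1c(C(=O)Nc2ccccc2)cc2ccccc21`: > 100000 nM
compound 2, `CN(Cc1ccccc1)C(=O)c1cc2ccccc2[nH]1`: 1600 nM
compound 3, `c1ccc(NCc2cc3ccccc3[nH]2)cc1`: 320 nM

In an assay for inhibition of Amine oxidase [flavin-containing] B (Bos taurus), read by fluorescence (on this read-out higher numbers stand for weaker inhibition and lower numbers for stronger inhibition), compound 3 shows the lowest number of the two numbers measured; compound 2 sits higher, with the gap lying beyond the usual scatter. Compound 1 gives only a limit, (the limit of > 100000 nM in this assay, at which 1 of the 3 values shown sits), and not a number; it too carries a methyl on an aromatic nitrogen.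

Compound 4, `Cn1c(CNc2ccccc2)cc2ccccc21`, differs from compound 3 by methyl in place of hydrogen on an aromatic nitrogen. Among the measured compounds shown here, no measured pair isolates this change. The limit of compound 1 suggests the hydrogen may matter, so a weakening step is expected, a 7.8-fold higher number from compound 3 to compound 4 (0.89 log units; beyond the scatter). Compound 4 is therefore estimated at 2500 nM, within 500 nM to 15000 nM.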

Compound 4, inhibition constant: 75000 nM
Compound 4: middle estimate off by 30-fold (1.48 log units), on the low side; the measured number lies above the stated range.
By their numbers in this assay, from the lowest: compound 3; then compound 2; then compound 4. At a limit, above all of these: compound 1.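

Swapping the hydrogen on the aromatic nitrogen for a methyl, a change of a single carbon, gives a 230-fold higher number from compound 3 to compound 4 (2.37 log units; beyond the scatter). Among the compounds shown here, this is the first measured pair to isolate this position, and it shows that the position is highly sensitive to this change. Compound 1, which carries the same methyl, gives only a limit and not a number: the limit of > 100000 nM in this assay, at which 1 of the 4 values shown sits.

The compounds shown cannot separate the effect of removing the hydrogen from that of adding the carbon. As far as these compounds go, how an ethyl group or a longer chain on this nitrogen would read remains open.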